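From pentyloxy to isopropylsulfanyl on the shared core

A few compounds are considered here, and "the series" means these few. Any claim that something is new, unique, unknown or untested is made for them only; others in the source may bear on it.

Compound 1 `Nc1nc(N2CCCC2)c2ncn(/C=C3/CC3(CO)CO)c2n1`: "not determined" (no result reported)
Compound 2 `CCCCCCSc1nc(N)nc2c1ncn2/C=C1/CC1(CO)CO`: > 20000 nM
Compound 3 `CCCCCOc1nc(N)nc2c1ncn2/C=C1/CC1(CO)CO`: > 20000 nM

In an ADME assay on MOLT-3 cells (Homo sapiens) for cytotoxicity, with a stated time of 7 days (on this read-out higher numbers stand for lower toxicity in this test and lower numbers for higher toxicity in this test), compound 3 gives > 20000 nM, which is a limit and not a number. Compound 2 also gives a limit, > 20000 nM. Together they make up (the limit of > 20000 nM in this assay, at which 2 of the 3 values shown sit).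

Compound 4 `CC(C)Sc1nc(N)nc2c1ncn2/C=C1/CC1(CO)CO` carries isopropylsulfanyl in place of pentyloxy on an aromatic carbon. Within the data shown here, the one measured step that bears on this is a step that the two limits leave unreadable from compound 2 to compound 3, which also exchanges a sulfanyl chain and pentyloxy, so it offers no size to carry over. In this assay the expectation is therefore no step beyond the scatter, an estimated a number no higher from compound 3 to compound 4 (the limit leaves the size open). Compound 4 is expected at 20000 nM, with an estimated range of 9000 nM to 30000 nM.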

Compound 4, half-maximal cytotoxic concentration: > 20000 nM
Compound 4 ended at the assay's limit (the forecaster's own chance of this, stated with the estimate: 75%); the middle value lies on the limit itself.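

The steps among compound 2, compound 3 and compound 4 cannot be read, because each compound gives a limit and not a number: the limit of > 20000 nM in this assay, at which 3 of the 4 values shown sit.

The compounds shown leave open whether these side chains differ at all in this assay.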